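Charged tail variants: notes on compound 3 and compound 4

The compounds below may be only part of what the source reports. "The series", "measured", "known", "first", "only" and "open" are said of these compounds alone.

The members of this series share one core, a fluorinated aryl amide and a long chain ending in a charged nitrogen group; they differ only at that end group. In an assay on LX2 cells for inhibition of COL1A1 promoter (Homo sapiens), read by a luciferase reporter, with a stated time of 24 h, tested at 20 uM (on this read-out higher numbers stand for a stronger effect at the one concentration tested and lower numbers for a weaker effect), compound 1 `CN(C)c1ccc2c(=O)c(C(=O)Nc3cc(F)cc(F)c3)cn(-c3ccc(OCCCCCCC[N+]4(C)CCCCC4)cc3F)c2n1` is reported as "not active" (no number reported), and no number is given for it. Compound 2 `CN(C)c1ccc2c(=O)c(C(=O)Nc3cc(F)cc(F)c3)cn(-c3ccc(OCCCCCCC[n+]4ccccc4)cc3F)c2n1` gives 15.4% in this assay, the only single figure in the set. Compound 3 `CC[N+]1(CCCCCCCOc2ccc(-n3cc(C(=O)Nc4cc(F)cc(F)c4)c(=O)c4ccc(N(C)C)nc43)c(F)c2)CCCCC1` is reported in this assay as "not active" (no number reported), again without a number. Compound 3 thus stands without a single value, and one further member of the set, compound 1, is in the same position, so nothing orders compound 3 against the others.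

Compound 4 `CC[N+]1(CCCCCCCOc2ccc(-n3cc(C(=O)Nc4cc(F)cc(F)c4)c(=O)c4ccc(N(C)C)nc43)c(F)c2)CCCC1` differs from compound 3 by a group of 7 heavy atoms (6 carbon, 1 nitrogen; one five-membered non-aromatic ring with 1 hetero atom) in place of a group of 8 heavy atoms (7 carbon, 1 nitrogen; one six-membered non-aromatic ring with 1 hetero atom), on a saturated chain carbon, seven bonds along the chain from an oxygen on an aromatic ring. For the measured compounds named here, no step between two measured compounds is available to calibrate the change. The one numbered result, that of compound 2 at 15.4%, is itself small, and compound 3 returned no number, so for compound 4 a shift of no more than the usual scatter, in no fixed direction, is expected in this assay. Compound 4 is accordingly estimated at 8% in this assay, within 0% to 22%, with a real chance that again no number is reported.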

Compound 4, a percentage reported as inhibition, at one concentration (the size of the read-out at that concentration, not a potency): "not active" (no number reported)
No number was reported for compound 4; no gap can be computed for the estimate.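

In this assay compound 3 gives "not active" (no number reported) and compound 4 gives "not active" (no number reported), so no step can be read between these two compounds. The compounds shown leave open whether the six-membered or the five-membered non-aromatic ring on the chain makes any difference in this assay. No available evidence bears on this result.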